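The compounds below may be only part of what the source reports. "The series", "measured", "known", "first", "only" and "open" are said of these compounds alone.

Measured so far:
- compound 1 `COc1ccc(/C(C)=C(/C)C(=O)NC2CC2)cc1`: 300 mg/kg
- compound 2 `C=CCNC(=O)/C(C)=C(/C)c1ccccc1`: 400 mg/kg
- compound 3 `C=CCNC(=O)/C(C)=C(/C)c1ccc(C)cc1`: 400 mg/kg

All three were tested in a toxicity assay on the whole organism (strain Icem-CET (SPF Caw)) for cytotoxicity, with Mus musculus as the target; a higher number here means that more compound is needed for the effect, a lower number that less compound is needed. Compound 2 stands level with compound 3 at the digits shown, and together the two give the highest of the three numbers; compound 1 lies a little lower, but that gap is within the usual scatter, so none of the three can be set apart from the others. For the measured compounds named here, the one step measured between single-change neighbours, no change at the digits printed from compound 2 to compound 3 (within the scatter), shows that a methyl in place of hydrogen on an aromatic carbon left the read-out unchanged.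

Compound 4 `C/C(C(=O)NC1CC1)=C(\C)c1ccccc1` is not yet measured. It differs from compound 2 by cyclopropyl in place of allyl on an amide-type nitrogen. Going by the values given here, no measured pair isolates this exact change: compound 1 carries a cyclopropyl on its amide nitrogen, but it differs from compound 2 in a second place as well, so its value can only hint that such amides stay in the same region. With that hint and no step beyond the scatter anywhere in this set, compound 4 is expected to show a 1.1-fold lower number from compound 2 to compound 4 (0.06 log units; within the scatter) in this assay. The estimate for compound 4 is 350 mg/kg, within a range of 200 mg/kg to 700 mg/kg.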

Compound 4, dose for half-maximal effect: 300 mg/kg
For compound 4 the middle estimate is 1.2-fold (0.07 log units) above the measured one; measured number inside the range.
By their numbers in this assay, from the lowest: compounds 1, 4, 2 and 3 (each within the scatter of the next).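

With everything else held the same, cyclopropyl in place of allyl on the amide-type nitrogen gives a 1.3-fold lower number from compound 2 to compound 4 (0.12 log units; within the scatter) in this assay and so, at this position, a closed ring of three carbons cannot be told apart from an open allyl group. Hydrogen in place of methoxy on an aromatic carbon gives no change at the digits printed from compound 1 to compound 4 (within the scatter) and shows, with cyclopropyl on the nitrogen, that this aromatic change also stays inside the scatter. No supporting information is available to account for either result.

Going by these compounds, only allyl and cyclopropyl appear on the amide nitrogen here, so it remains open whether a longer chain or a group carrying an amine or a carboxylic acid would move the number beyond the scatter. The same question stands for chlorine or a nitrile on the aromatic ring.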